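Swapping the ring-amine substituent on a urea

The compounds below may be only part of what the source reports. "The series", "measured", "known", "first", "only" and "open" are said of these compounds alone.

Compound 1 `O=C(Nc1ccc(Cl)c(C(F)(F)F)c1)N[C@H]1CCN(c2ccc3nncn3n2)C1` carries a urea bound to a saturated five-membered ring that bears a bicyclic aromatic group on its amine nitrogen. In an assay on a protein complex for displacement of a labelled ligand from CDK8/Cyclin C (Homo sapiens), read by TR-FRET, with a stated time of 1 h (a higher number here means a weaker inhibitor, a lower number a stronger inhibitor), compound 1 gives 4.2 nM, the lowest of the two numbers available. Its mirror-drawn partner, compound 2 `O=C(Nc1ccc(Cl)c(C(F)(F)F)c1)N[C@@H]1CCN(c2ccc3nncn3n2)C1`, gives 166 nM in this assay, and the step of a 40-fold higher number from compound 1 to compound 2 (1.60 log units; beyond the scatter) stands out (the fact that compounds 1 and 2 differ only in the configuration as drawn).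

Compound 3 `Nc1nccc(N2CC[C@H](NC(=O)Nc3ccc(Cl)c(C(F)(F)F)c3)C2)n1` keeps the urea, the chloro-trifluoromethylphenyl group and the drawn configuration of compound 1 but changes the aromatic group on the ring amine: a group of 7 heavy atoms (4 carbon, 3 nitrogen; one six-membered aromatic ring with 2 hetero atoms) in place of a group of 9 heavy atoms (5 carbon, 4 nitrogen; one five-membered aromatic ring with 3 hetero atoms, one six-membered aromatic ring with 2 hetero atoms), on an amine nitrogen in a ring.

Among the measured compounds shown here, no measured step touches this position; the only step recorded, the configurational one from compound 1 to compound 2, says nothing about what a smaller aromatic group on the ring amine would do. The expectation therefore rests on compound 1 alone and carries wide uncertainty. Compound 3 is expected to remain a strong inhibitor with a possible modest loss, so the estimated step is a 3.6-fold higher number from compound 1 to compound 3 (0.55 log units; beyond the scatter). Compound 3 is estimated at 15 nM in this assay, within a range from 3 nM to 80 nM.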

Compound 3, half-maximal inhibitory concentration in the CDK8/Cyclin C assay: 42.3 nM
Compound 3: the middle estimate sits 2.8-fold (0.45 log units) below what was measured; the measured number falls inside the stated range.
By their numbers in the CDK8/Cyclin C assay, from the lowest: compound 1; then compound 3; then compound 2.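

In the CDK8/Cyclin C assay, the exchange of the bicyclic group on the ring amine for 2-aminopyrimidin-4-yl gives a 10-fold higher number from compound 1 to compound 3 (1.00 log units; beyond the scatter), so the group at this position bears on the strength of inhibition, something the earlier pair could not show because its two compounds carry the same group there and differ only at a stereocentre. The loss is not the whole effect of the change, since the same exchange also comes with a large gain in solubility, and compound 3 therefore gives up strength of inhibition while becoming far more soluble: the measured solubility of compound 1, 1000 nM, and of compound 3, 30300 nM, a 30-fold higher number (1.48 log units; beyond the scatter) In a physicochemical assay for solubility, measured as kinetic solubility (a lower number here means a less soluble compound, a higher number a more soluble compound), compound 1 gives 1000 nM and compound 3 gives 30300 nM. Neither read-out alone describes this exchange, and at this position the better number in one assay goes with the poorer number in the other, at least for this single pair.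

The step removes the five-membered aromatic ring and adds the amino group at once, so the compounds shown cannot say which of the two parts accounts for either shift. As far as these compounds go, it also stays open whether a pyrimidin-4-yl group without the amine, or a morpholine or a carboxylic acid on the aromatic ring, would keep the solubility and recover the strength of compound 1.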